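Removing one fluorine from a low-toxicity diaryl ether scaffold

The source may report more compounds than this note shows. Statements on the series, on what has been measured and on what is new or still open speak of the compounds shown alone.

Compound 1 `N#Cc1ccc(Nc2nccc(Oc3ccc(-c4ccc(C#N)cc4)cc3Cl)n2)cc1`: in a functional assay on MT4 cells (Homo sapiens) for cytotoxicity, read by MTT assay, with a stated time of 5 days (on this read-out higher numbers stand for lower toxicity in this test and lower numbers for higher toxicity in this test), compound 1 gives > 295000 nM, which is a limit of the test rather than a number.
Compound 2 `Cc1cc(-c2ccc(Oc3ccnc(Nc4ccc(C#N)cc4)n3)c(F)c2)ccc1C#N`: in this assay compound 2 gives > 296000 nM, again a limit.
Compound 3 `N#Cc1ccc(Nc2nccc(Oc3ccc(-c4ccc(C#N)cc4)c(F)c3F)n2)cc1`: in this assay compound 3 gives > 294000 nM, also a limit.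

All three measured compounds share one core and differ only in the substituents on the central ring carrying the ether and in the group on the outer ring. None of them reached a measurable toxic concentration in this assay; each result sits at the highest concentration tested, so the three cannot be ranked against one another, and compound 3 stands with the other two at that limit.

Compound 4 `N#Cc1ccc(Nc2nccc(Oc3ccc(-c4ccc(C#N)cc4)cc3F)n2)cc1` is not yet measured. It differs from compound 3 by hydrogen in place of fluoro on an aromatic carbon. Every compound seen so far is at the limit of this assay, so the change is expected to give no step beyond the usual scatter. The expected step that the limit leaves unreadable from compound 3 to compound 4 is therefore essentially none. Compound 4 is expected to give about 300000 nM, within a range from 100000 nM to 900000 nM, most likely reported again as a limit.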

Compound 4, half-maximal cytotoxic concentration: > 307000 nM
Compound 4 gave a limit, no number; the forecaster's own chance of this, stated with the estimate: 90%; middle value at least 1.0-fold (0.01 log units) away from the limit.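

In this assay, for the compounds shown here, compound 4 also ends at a limit, as do compound 1, compound 2 and compound 3, so no step between them can be read. The compounds shown leave open whether fluoro, chloro, methyl or hydrogen on these aromatic carbons makes any difference to toxicity, and at what concentration any of the four would harm these cells.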